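The source may report more compounds than this note shows. Statements on the series, on what has been measured and on what is new or still open speak of the compounds shown alone.

In a toxicity assay on MDCK cells (Canis lupus familiaris) for cytotoxicity, read by crystal violet staining, with a stated time of 48 h (a higher number here means that more compound is tolerated, a lower number that less compound is tolerated), compound 3 `Cc1ccc2[nH]c(=O)c(CN(Cc3ccc(OC(F)F)cc3)Cc3ccc(C(C)(C)C)cc3)cc2c1` stands only at a limit, giving > 5000 nM, which is a limit of the assay and not a number. Compound 2 `Cc1ccc2[nH]c(=O)c(CN(Cc3ccc(C(N)=O)cc3)Cc3ccc(C(C)(C)C)cc3)cc2c1` likewise gives > 5000 nM, a limit. Compound 1 `Cc1ccc2[nH]c(=O)c(CN(Cc3ccc(OCC(=O)OC(C)(C)C)cc3)Cc3ccc(C(C)(C)C)cc3)cc2c1` gives > 10000 nM, again a limit. The three steps among them, a step that the two limits leave unreadable from compound 1 to compound 2, a step that the two limits leave unreadable from compound 1 to compound 3 and a step that the two limits leave unreadable from compound 2 to compound 3, therefore carry no readable size, as the limit of > 10000 nM in this assay, at which 1 of the 3 values shown sits, and the limit of > 5000 nM in this assay, at which 2 of the 3 values shown sit, show. Compound 4 `Cc1ccc2[nH]c(=O)c(CN(Cc3ccc(N(C)C)cc3)Cc3ccc(C(C)(C)C)cc3)cc2c1` differs from compound 3 by dimethylamino in place of difluoromethoxy on an aromatic carbon. Among the measured compounds shown here, no measured step bears on this change with a readable size, so for compound 4 nothing beyond the scatter is expected in this assay, and the step from compound 3 is estimated as a step that the limit leaves unreadable from compound 3 to compound 4. Compound 4 is accordingly expected to give about 10000 nM, within a range of 3000 nM to 30000 nM.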

Compound 4, half-maximal cytotoxic concentration: > 5000 nM
Compound 4: a limit, no number (the forecaster's own chance of this, stated with the estimate: 75%); the middle value lies beyond the limit too.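

Compound 4 stands at a limit, as do compound 1, compound 2 and compound 3, so none of the steps joining compound 4 to them can be read. The compounds shown leave open at what concentration any of the four becomes cytotoxic in this assay.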